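The compounds below may be only part of what the source reports. "The series", "measured", "known", "first", "only" and "open" are said of these compounds alone.

Measured compounds:
Compound 1 `O=C(Nc1cccc(-n2cc(-c3ccncc3)c(-c3cc(O)cc(Cl)c3)n2)c1)Nc1ccc(Cl)c(C(F)(F)F)c1` gives 92% in a functional assay on ACHN cells (Homo sapiens) for inhibition, read by sulforhodamine B assay, with a stated time of 48 h, tested at 1 uM; a higher number here means a weaker effect of the compound at the concentration tested, a lower number a stronger effect.
Compound 2 `O=C(Nc1cccc(-n2cc(-c3ccncc3)c(-c3cc(O)cc(Cl)c3)n2)c1)Nc1ccc(Cl)c(Cl)c1` gives 79% in this assay.

Compound 1 stands highest of the two numbers in this assay; its nearest neighbour is compound 2, and the step of a number 13 percentage points lower from compound 1 to compound 2 (beyond the scatter) came with chloro in place of trifluoromethyl on an aromatic carbon. Compound 3 `COc1cc(Cl)cc(-c2nn(-c3cccc(NC(=O)Nc4ccc(Cl)c(C(F)(F)F)c4)c3)cc2-c2ccncc2)c1` differs from compound 1 by methyl in place of hydrogen on an oxygen on an aromatic ring. No measured step touches this oxygen, so nothing shown bears directly on the change; the expectation is therefore no step beyond the scatter, a number 2 percentage points lower from compound 1 to compound 3 (within the scatter). Compound 3 is estimated at 90%, within 76% to 100%.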

Compound 3, a percentage reported as activity, at one concentration (the size of the read-out at that concentration, not a potency): 45%
Estimate against measurement, compound 3: 45 percentage points above, and the stated range ends above it.
By their numbers in this assay, from the lowest: compound 3; then compound 2; then compound 1.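

In this assay, the change from hydroxy to methoxy gives a number 47 percentage points lower from compound 1 to compound 3 (beyond the scatter), so this oxygen is a sensitive position, and a single added methyl there shifts the read-out further than the change from trifluoromethyl to chloro did. The lower number means a stronger effect at the concentration tested, with the methoxy present on the core of compound 1. Nothing available explains why. As far as these compounds go, it remains open whether an ethoxy group or an amine at this position would act likewise, and whether the same methyl would have a similar effect on compound 2.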